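Removing One Methoxy Group: Compound 3 to Compound 4

A few compounds are considered here, and "the series" means these few. Any claim that something is new, unique, unknown or untested is made for them only; others in the source may bear on it.

Measured so far in a functional assay on Huh-7 cells (Homo sapiens) for inhibition, read by sulforhodamine B assay, with a stated time of 72 h; on this read-out lower numbers stand for stronger inhibition and higher numbers for weaker inhibition:
Compound 1 `COc1ccc(C(=O)/C=C/c2cn(-c3ccccc3)nc2-c2ccsc2)c(OC)c1` gives 3000 nM.
Compound 2 `COc1cc(OC)c(C(=O)/C=C/c2cn(-c3ccccc3)nc2-c2cccnc2)c(OC)c1` gives 500 nM.
Compound 3 `COc1ccc(C(=O)/C=C/c2cn(-c3ccccc3)nc2-c2cccnc2)c(OC)c1OC` gives 2300 nM.

Among these three numbers, compound 3 stands second highest. Its number sits close to that of compound 1, a gap within the usual scatter, while compound 2 lies well below it, a gap beyond the scatter. Compound 4 `COc1ccc(C(=O)/C=C/c2cn(-c3ccccc3)nc2-c2cccnc2)c(OC)c1` differs from compound 3 by hydrogen in place of methoxy on an aromatic carbon. For the measured compounds named here, no measured pair shows this exact change, so its size is open. Because compound 1, which also carries two methoxy groups, gives 3000 nM, no step beyond the scatter is expected in either direction. Compound 4 is therefore estimated at 2500 nM, within 800 nM to 8000 nM, meaning an expected 1.1-fold higher number from compound 3 to compound 4 (0.04 log units; within the scatter).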

Compound 4, half-maximal inhibitory concentration: 2400 nM
For compound 4 the middle estimate is 1.0-fold (0.02 log units) above the measured one; the measured number falls inside the stated range.
By their numbers in this assay, from the lowest: compound 2; then compounds 3, 4 and 1 (each within the scatter of the next).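

Removing the methoxy group that sits ortho to two methoxy groups gives a 1.0-fold higher number from compound 3 to compound 4 (0.02 log units; within the scatter), so at this position hydrogen and methoxy cannot be told apart. The same kind of swap at another place on that ring gives a 4.8-fold higher number from compound 2 to compound 4 (0.68 log units; beyond the scatter), so the outcome depends on which methoxy group leaves. Putting pyridin-3-yl in place of thiophen-3-yl gives a 1.3-fold lower number from compound 1 to compound 4 (0.10 log units; within the scatter), and no measurement at hand explains any of these steps.

From the compounds shown here alone, it remains open whether an amine or a longer alkoxy chain at this position would shift the number. Also open, going by these compounds, is whether the large step seen with compound 2 would hold with thiophen-3-yl in place of pyridin-3-yl.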